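The compounds below may be only part of what the source reports. "The series", "measured", "known", "first", "only" and "open" are said of these compounds alone.

Measured so far:
Compound 1 `O=C(CC1c2ccccc2N=C(SCCCCCN2CCCC2)N1c1ccc(-c2ccc(F)cc2)cc1)NCc1ccc(F)cc1`: 12600 nM
Compound 2 `CN(C)CCCCCSC1=Nc2ccccc2C(CC(=O)NCc2ccccc2)N1c1ccccc1`: 18500 nM
Compound 3 `CN(C)CCCCCSC1=Nc2ccccc2C(CC(=O)NCc2ccc(F)cc2)N1c1ccc(-c2ccc(F)cc2)cc1`: 400 nM

Of the compounds shown here, three have been tested in an assay on cells for inhibition of Voltage-dependent T-type calcium channel subunit alpha-1G (Homo sapiens), read by patch clamp; on this read-out lower numbers stand for stronger inhibition and higher numbers for weaker inhibition. Compound 3 gives 400 nM and is the strongest inhibitor of the three. Compound 1 differs from compound 3 in one place: pyrrolidin-1-yl in place of dimethylamino on a saturated chain carbon, five bonds along the chain from a sulfur. This single change brings a large step, a 32-fold higher number from compound 3 to compound 1 (1.50 log units; beyond the scatter), so the pyrrolidin-1-yl group weakens inhibition markedly on this core. Compound 2, with 18500 nM, stands with compound 1 within the usual scatter of the method, while the gap to compound 3 is well beyond it. The difference between the cores of compound 2 and compound 3 is not broken down here.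

Compound 4 `O=C(CC1c2ccccc2N=C(SCCCCCN2CCCC2)N1c1ccccc1)NCc1ccccc1` has not been measured. It relates to compound 2 as compound 1 relates to compound 3: pyrrolidin-1-yl in place of dimethylamino on a saturated chain carbon, five bonds along the chain from a sulfur. Going by the values given here, this is the same change, at the same place, as the one from compound 3 to compound 1. Since compound 2 already sits at a weak level, an equally large step could carry compound 4 toward the edge of what this assay can report, so a weaker number is expected but its size is uncertain; the estimated step is a 2.7-fold higher number from compound 2 to compound 4 (0.43 log units; beyond the scatter), resting on the step from compound 3 to compound 1. For compound 4 the estimate is 50000 nM, with a range from 12000 nM to 250000 nM.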

Compound 4, half-maximal inhibitory concentration: 77000 nM
The estimate for compound 4 lay 1.5-fold (0.19 log units) below the measured number; the measured number falls inside the stated range.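

In this assay pyrrolidin-1-yl again gives weaker inhibition than dimethylamino, with a 4.2-fold higher number from compound 2 to compound 4 (0.62 log units; beyond the scatter), so on the two cores shown the direction of this change carries over from one core to the other. The size of the step does not carry over, and a step measured on one core would be a poor guide to the exact number on the other: the same change on two cores in this assay, a 32-fold higher number (1.50 log units; beyond the scatter) from compound 3 to compound 1 and a 4.2-fold higher number (0.62 log units; beyond the scatter) from compound 2 to compound 4, 7.6-fold (0.88 log units) apart, beyond the scatter of two such steps These two cores differ in more than one place, and the compounds shown do not tell which of those differences sets the size of the step, nor do two cores show that the direction will hold on every other core in the series.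

Going by these compounds, it remains open whether other amines at the end of the chain, such as piperidin-1-yl, morpholin-4-yl or diethylamino, would track dimethylamino or pyrrolidin-1-yl, and whether a shorter or longer chain between the sulfur and the amine would change the picture. Also open, on these data alone, is how large the step would be on a core carrying only one of the differences between the core of compound 2 and the core of compound 3.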